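The source may hold more compounds than are shown below. What is called first, only, known or untested is meant among the compounds shown, and "the series" means these compounds.

a functional assay on the whole organism (strain Sprague-Dawley) for inhibition, with Rattus norvegicus as the target, with a stated time of 10 min (on this read-out lower numbers stand for an effect already at smaller amounts and higher numbers for an effect only at larger amounts of compound), was used for every compound here. Going by these compounds, compound 1 `O=C(O)c1cnc(-c2ccccc2[N+](=O)[O-])[nH]c1=O` gives only a limit in this assay, > 50 mg/kg, so its exact place among the numbers stays open. Compound 2 `Nc1ccccc1-c1ncc(C(=O)O)c(=O)[nH]1` gives 50 mg/kg in this assay, and compound 3 `O=C(O)c1cnc(-c2ccccc2OCc2ccccc2)[nH]c1=O` gives 5 mg/kg. Compound 4 `C[S+]([O-])c1ccccc1-c1ncc(C(=O)O)c(=O)[nH]1` is not yet measured; it differs from compound 1 thus: a group of 3 heavy atoms (1 carbon, 1 oxygen, 1 sulfur; no ring) in place of a group of 3 heavy atoms (1 nitrogen, 2 oxygen; no ring), on an aromatic carbon. Two measured steps also swap out the nitro group: a number no higher from compound 1 to compound 2 (the limit leaves the size open) and an at least 10-fold lower number from compound 1 to compound 3 (1.00 log units; beyond the scatter). The first cannot be sized, since compound 1 sits at the limit of > 50 mg/kg in this assay, at which 1 of the 3 values shown sits; the second is modest. A change to another small, uncharged group is expected to give at most a small lowering, and compound 4 is estimated at 40 mg/kg, between 15 mg/kg and 100 mg/kg, meaning an at least 1.2-fold lower number from compound 1 to compound 4 (0.09 log units; that floor lies within the scatter).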

Compound 4, dose for 50% inhibition: > 5 mg/kg
Compound 4: a limit, no number; the forecaster's own chance of this, stated with the estimate: 40%; the middle value lies beyond the limit too.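

Compound 4 gives only a limit, > 5 mg/kg. Even so, this adds one reading at this position: with the sulfur-bearing group in place of benzyloxy on the aromatic carbon, the result is a number no lower from compound 3 to compound 4 (the limit leaves the size open), so this group does not improve on the benzyloxy group of compound 3. The steps to compound 4 from compound 1 and from compound 2 cannot be read.

Going by these compounds, how far the number for compound 4 lies from that of compound 3 stays open. So does whether a shorter ether such as methoxy, or a plain alkyl chain, would keep the low number seen with benzyloxy.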